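The source may hold more compounds than are shown below. What is called first, only, known or untested is meant among the compounds shown, and "the series" means these compounds.

Going by the values given here, in an assay on cells for agonist activity at ecdysone receptor (Bombyx mori), read by a luciferase reporter, with a stated time of 24 h (a higher number here means that more compound is needed for the effect, a lower number that less compound is needed), compound 2 `CC(C)c1ccc(C(=O)NN(C(=O)c2ccccc2Cl)C(C)(C)C)cc1` gives 24.6 nM, the lowest of the two numbers so far. Among the compounds with values here, compound 1 `Cc1cccc(C(=O)NN(C(=O)c2ccccc2Cl)C(C)(C)C)c1` gives 603 nM in this assay, a gap beyond the scatter, though the two differ at more than one place and no single step between them is counted. Compound 3 `COc1ccc(C(=O)NN(C(=O)c2ccccc2Cl)C(C)(C)C)cc1` is reached from compound 2 by methoxy in place of isopropyl on an aromatic carbon. Within the data shown here, no measured step covers this change, so the expectation rests only on compound 2; the step from compound 2 to compound 3 is expected to be a loss beyond the scatter, a 6.1-fold higher number from compound 2 to compound 3 (0.79 log units; beyond the scatter). Compound 3 is estimated at 150 nM in this assay, with a range from 40 nM to 600 nM.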

Compound 3, half-maximal effective concentration: 51.3 nM
For compound 3 the middle estimate is 2.9-fold (0.47 log units) above the measured one; the range from low to high includes it.
By their numbers in this assay, from the lowest: compound 2; then compound 3; then compound 1.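

In this assay, methoxy in place of isopropyl on an aromatic carbon, para to a large group, is a modest loss: a 2.1-fold higher number from compound 2 to compound 3 (0.32 log units; beyond the scatter). This position therefore holds both groups with the number staying well short of that of compound 1. The change of 3-methylphenyl to 4-methoxyphenyl on a carbonyl carbon is large, a 12-fold lower number from compound 1 to compound 3 (1.07 log units; beyond the scatter), but it alters both group and place at once. Nothing available gives a reason for either step.

Open, as far as these compounds go, is how an amine or a longer chain at this position would read. Also open, from the compounds shown here alone, is how much of the large step belongs to the place alone, with one group held constant.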